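The source may report more compounds than this note shows. Statements on the series, on what has been measured and on what is new or still open speak of the compounds shown alone.

Series notes. Compound 1 `CCCC1=C(N2CC2)C(=O)C(C(COC(N)=O)OC)=C(N2CC2)C1=O` gives 4.64 in a functional assay on L1210 cells (Mus musculus), with a stated time of 1 days; on this read-out lower numbers stand for lower potency and higher numbers for higher potency (the scale is a negative logarithm). Among the measured compounds shown here, compound 2 `CCCC1=C(N2CC2)C(=O)C(CCC)=C(N2CC2)C1=O` gives 4.14 in this assay, and the step of a number 0.50 log units lower from compound 1 to compound 2 (beyond the scatter) is the only single-site comparison among the measured compounds; it concerns a different site from the one changed here. Compound 3 `CCC1=C(N2CC2)C(=O)C(CCOC(N)=O)=C(N2CC2)C1=O` gives 4.88, the highest of the three numbers, though compound 1 sits within the scatter of it and only compound 2 lies beyond the scatter below it. Compound 4 `CCCC1=C(N2CC2)C(=O)C(CCOC(N)=O)=C(N2CC2)C1=O` has not yet been measured. It differs from compound 3 by methyl in place of hydrogen on a saturated chain carbon, two bonds along the chain from a double-bonded ring carbon, which read one bond further out is ethyl to propyl. For the measured compounds named here, no measured step bears directly on this change: compound 1 and compound 3 differ from each other in two places, and the gap between their values is within the scatter, so they offer no separate reading of ethyl to propyl. The step from compound 1 to compound 2 alters a different site and is not a guide either. With nothing showing that this change moves the number, a step of no change at the digits printed from compound 3 to compound 4 (within the scatter) is expected, within the scatter. Compound 4 is therefore estimated at 4.88, with a range from 4.5 to 5.25.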

Compound 4, logarithm of the reciprocal of the active concentration, log(1/C): 4.42
Compound 4: the middle estimate sits 0.46 log units above what was measured, outside the stated range (below it).
By their numbers in this assay, from the lowest: compounds 2, 4, 1 and 3 (each within the scatter of the next, the first and the last beyond it).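

In this assay, methyl in place of hydrogen on a saturated chain carbon, two bonds along the chain from a double-bonded ring carbon, now has a direct reading: a number 0.46 log units lower from compound 3 to compound 4 (beyond the scatter) shows that ethyl to propyl moves the number at this position, at least with the carbamoyloxy-bearing chain held fixed. At the other chain, with propyl held fixed, carbamoyloxy in place of methyl gives a number 0.28 log units higher from compound 2 to compound 4 (within the scatter) and hydrogen in place of methoxy gives a number 0.22 log units lower from compound 1 to compound 4 (within the scatter) so neither change is resolved alone, even though the two together give a number 0.50 log units lower from compound 1 to compound 2 (beyond the scatter) and thus a step beyond the scatter. No measurement shown accounts for the step from ethyl to propyl.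

On these data alone, the reading at this position rests on a single pair, so whether it holds when the other chain carries the methoxy group or a plain propyl stays open. Also open, as far as these compounds go, is how the number runs with methyl or a longer chain such as butyl at this position, and whether a hydroxyl or an amine in place of carbamoyloxy separates from the values seen so far.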